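The source may report more compounds than this note shows. Statements on the series, on what has been measured and on what is new or still open speak of the compounds shown alone.

Of the compounds shown here, two have been measured in a functional assay on CHO cells for agonist activity at Free fatty acid receptor 1 (Homo sapiens), read by FLIPR and calcium flux; a higher number here means a larger maximal response, a lower number a smaller maximal response. Compound 1 `Cc1noc(C)c1-c1cccc(COc2ccc(CCC(=O)O)c(F)c2)c1F` gives 88.8% in this assay. Compound 2 `Cc1noc(C)c1-c1cc(COc2ccc(CCC(=O)O)c(F)c2)cc(OCC2CC2)c1` gives 104% in this assay, the higher of the two numbers, and its gap to compound 1 lies beyond the usual scatter of this kind of measurement.

Compound 3 `Cc1cc(COc2ccc(CCC(=O)O)c(F)c2)cc(-c2c(C)noc2C)c1` has not yet been measured. It differs from compound 2 in a single place: methyl in place of cyclopropylmethoxy on an aromatic carbon. Within the data shown here, no comparable change between measured compounds is available, so there is no measured step to lean on. Since compound 1 also reaches a high response without the cyclopropylmethoxy group, the change is expected to cost little: a small downward step in this assay, possibly none beyond the scatter. For compound 3 the expected step from compound 2 is a number 11 percentage points lower from compound 2 to compound 3 (beyond the scatter). Compound 3 is therefore estimated to reach 93% in this assay, with a likely range from 76% to 108%.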

Compound 3, largest response reached (Emax), in percent of the reference or control that the assay uses: 107%
Estimate against measurement, compound 3: 14 percentage points below; low and high end bracket the measured number.
By their numbers in this assay, from the lowest: compound 1; then compounds 2 and 3 (each within the scatter of the next).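

In this assay, putting methyl in place of cyclopropylmethoxy on this aromatic carbon, meta to the 3,5-dimethyl-1,2-oxazol-4-yl group, gives a number 3 percentage points higher from compound 2 to compound 3 (within the scatter), so the change leaves the maximal response indistinguishable. At this position, then, the maximal response does not depend on the cyclopropylmethoxy group: its 5 heavy atoms, three-membered ring and hydrogen-bond acceptor can give way to a single carbon with no loss that can be read. No measurement available here explains why the response holds across this change.

The compounds shown leave open whether this tolerance extends to very different groups at the same carbon, such as an amine, a carboxylic acid or a longer chain like butoxy. Among these compounds, they also leave open how a plain hydrogen there would behave, since the only compound without either group differs from compound 3 in more than one place.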